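Replacing oxan-4-yl with 1-methylcyclopropyl: an expected step

The compounds below may be only part of what the source reports. "The series", "measured", "known", "first", "only" and "open" are said of these compounds alone.

Two compounds have been measured in a physicochemical assay for solubility, using the shake flask method, in phosphate buffer, measured as kinetic solubility, with a stated time of 20 h, at pH 6.5; a higher number here means a more soluble compound, a lower number a less soluble compound:

Compound 1 `FC(F)(F)c1ccc(Nc2cc3[nH]c(-c4cccc(C(F)(F)F)c4)nc3cn2)nc1`: < 5000 nM, a limit of the assay
Compound 2 `FC(F)(F)c1ccc(Nc2cc3[nH]c(C4CCOCC4)nc3cn2)nc1`: 155000 nM

Going by the values given here, compound 2 holds the only actual number of the pair, as the entry for compound 1 is a limit. Among the compounds with values here, the one measured step is large: an at least 31-fold higher number from compound 1 to compound 2 (1.49 log units; beyond the scatter). One end of that step rests on (the limit of < 5000 nM in this assay, at which 1 of the 2 values shown sits).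

The next compound, compound 3 `CC1(c2nc3cnc(Nc4ccc(C(F)(F)F)cn4)cc3[nH]2)CC1`, keeps the shared core and differs from compound 2 at the same place: 1-methylcyclopropyl in place of oxan-4-yl on an aromatic carbon. Here, 1-methylcyclopropyl stands in place of oxan-4-yl on an aromatic carbon.

Within the data shown here, only one measured step bears on this change, and it involves a different incoming group. Of the two groups measured at this place, oxan-4-yl came with the actual number, with compound 2 at 155000 nM. With that group gone, a moderate step to a lower number is expected in this assay, smaller than the one measured. The estimated step is a 3.1-fold lower number from compound 2 to compound 3 (0.49 log units; beyond the scatter). The estimated value for compound 3 is 50000 nM, with an expected range from 12000 nM to 140000 nM.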

Compound 3, solubility: 188000 nM
For compound 3 the middle estimate is 3.8-fold (0.58 log units) below the measured one; the whole stated range lies below it.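

In this assay, the swap at this aromatic carbon between two ring nitrogen atoms gives a 1.2-fold higher number from compound 2 to compound 3 (0.08 log units; within the scatter), so the two non-aromatic groups cannot be told apart here, even though oxan-4-yl carries a ring oxygen and a six-membered ring while 1-methylcyclopropyl is a three-membered ring of carbon only. A second non-aromatic group now also stands well apart from 3-(trifluoromethyl)phenyl, with an at least 37-fold higher number from compound 1 to compound 3 (1.57 log units; beyond the scatter), which matches the earlier large step to compound 2 in direction. The entry for compound 1 is a limit of the assay, so the full size of both large steps stays unknown, and this one too rests on that limit at one end: the limit of < 5000 nM in this assay, at which 1 of the 3 values shown sits.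

Only one aromatic group has been tested at this place, so the compounds shown cannot separate the effect of leaving an aromatic ring from that of losing its trifluoromethyl group, which a plain phenyl could address. They also leave open whether an open chain such as tert-butyl, or a piperidine ring carrying an amine, would sit level with compound 2 and compound 3 in this assay.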